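Chloro for the amine side chain, second pair

The source may report more compounds than this note shows. Statements on the series, on what has been measured and on what is new or still open speak of the compounds shown alone.

Measured so far:
- compound 1, `CN(C)CCCNc1ccnc2cc(OCc3ccc(F)cc3)ccc12`: in a functional assay on DLD-1 cells (Homo sapiens) for cytotoxicity, read by MTT assay, with a stated time of 48 h (on this read-out higher numbers stand for weaker inhibition and lower numbers for stronger inhibition), compound 1 gives 2540 nM
- compound 2, `Fc1ccc(COc2ccc3c(Cl)ccnc3c2)cc1`: in this assay compound 2 gives 3230 nM
- compound 3, `C=CCOc1ccc2c(NCCCN(C)C)ccnc2c1`: in this assay compound 3 gives 5180 nM

Compound 4, `C=CCOc1ccc2c(Cl)ccnc2c1`, is not yet measured. It differs from compound 3 by chloro in place of (3-(dimethylamino)propyl)amino on an aromatic carbon. The same change has already been made once, from compound 1 to compound 2, as chloro in place of (3-(dimethylamino)propyl)amino on an aromatic carbon; there it gave a 1.3-fold higher number from compound 1 to compound 2 (0.10 log units; within the scatter). The place of the change is worded identically in both pairs, so this is the same change on a different core. The two cores differ by vinyl in place of 4-fluorophenyl on a saturated chain carbon bound to an oxygen on an aromatic ring, a difference that gave a 2.0-fold higher number from compound 1 to compound 3 (0.31 log units; beyond the scatter). Compound 3 has the highest number of the three, though its gap to compound 2 is within the scatter.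

Among the compounds with values here, the step from compound 3 to compound 4 is expected at a 1.3-fold higher number from compound 3 to compound 4 (0.11 log units; within the scatter), resting on a 1.3-fold higher number from compound 1 to compound 2 (0.10 log units; within the scatter), the only prior instance of this change, with added width for the single precedent. Compound 4 is estimated at 6700 nM in this assay, expected between 3000 nM and 15000 nM.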

Compound 4, half-maximal inhibitory concentration: 2890 nM
Estimate against measurement, compound 4: 2.3-fold (0.37 log units) above; the measured number lies below the stated range.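

In this assay chloro in place of (3-(dimethylamino)propyl)amino gives a 1.8-fold lower number from compound 3 to compound 4 (0.25 log units; within the scatter) and so stays inside the scatter on this second core, as it did on the first. The two pairs do not separate from each other: the same change on two cores in this assay, a 1.3-fold higher number (0.10 log units; within the scatter) from compound 1 to compound 2 and a 1.8-fold lower number (0.25 log units; within the scatter) from compound 3 to compound 4, 2.3-fold (0.36 log units) apart, within the scatter of two such steps. The change therefore carries across these two cores without a step beyond the scatter, but this rests on two pairs in a single cell read-out, so it neither settles the direction of the step nor shows that the side chain can be exchanged without consequence on other cores.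

The compounds shown leave open whether another amine on that aromatic carbon, such as a longer chain ending in a morpholine or piperidine ring, would give a step beyond the scatter. They also leave open how the chloro exchange behaves with a methyl or an unsubstituted benzyl on the ether oxygen.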